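The compounds below may be only part of what the source reports. "The series", "measured", "known", "first", "only" and "open" are said of these compounds alone.

Compound 1 `CCCSC[C@H](NC(C)=O)C(=O)CCl` gives 6900 nM in a functional assay on NALM-6 cells (Homo sapiens); on this read-out higher numbers stand for weaker inhibition and lower numbers for stronger inhibition; compound 2 `CCCCCSC[C@H](NC(C)=O)C(=O)CCl` gives 5800 nM; compound 3 `CCCCCCCCCCSC[C@H](NC(C)=O)C(=O)CCl` gives 4700 nM.

Compound 3 holds the lowest number of the three, yet its steps to the others lie within the scatter: a 1.2-fold lower number from compound 2 to compound 3 (0.09 log units; within the scatter) and a 1.5-fold lower number from compound 1 to compound 3 (0.17 log units; within the scatter). Compound 4 `CCCCCCCCCCCCCCCSC[C@H](NC(C)=O)C(=O)CCl` differs from compound 3 by pentyl in place of hydrogen on a saturated chain carbon, ten or more bonds along the chain from a sulfur. Going by the values given here, the steps that bear on this change are the earlier chain lengthenings, a 1.2-fold lower number from compound 1 to compound 2 (0.08 log units; within the scatter), a 1.2-fold lower number from compound 2 to compound 3 (0.09 log units; within the scatter) and a 1.5-fold lower number from compound 1 to compound 3 (0.17 log units; within the scatter), none of them beyond the scatter. Compound 4 is therefore expected to show no step beyond the scatter in this assay, a slight move toward a lower number at best, a 1.2-fold lower number from compound 3 to compound 4 (0.07 log units; within the scatter). Compound 4 is estimated at 4000 nM, with a range from 2000 nM to 9000 nM.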

Compound 4, half-maximal inhibitory concentration: 8900 nM
Estimate against measurement, compound 4: 2.2-fold (0.35 log units) below; the range from low to high includes it.
By their numbers in this assay, from the lowest: compounds 3, 2, 1 and 4 (each within the scatter of the next).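

In this assay, going by these compounds alone, pentyl in place of hydrogen on a saturated chain carbon, ten or more bonds along the chain from a sulfur, gives a 1.9-fold higher number from compound 3 to compound 4 (0.28 log units; within the scatter), the first step in this chain series printed toward a higher number. As that step stays within the scatter, it does not establish a reversal, and this position tolerates the longer chain without a step beyond the scatter. Nothing measured here accounts for the step.

From the compounds shown here alone, what stays open is whether an amine or a carboxylic acid at the end of the chain, or a still longer chain, would give a step beyond the scatter.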